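Removing a chain methyl from compound 2

This account rests on a few compounds, and the source may have more. Where it says the series, first, only, none or still open, it means among the compounds named here.

In a functional assay on a cell-free system (plasma, Homo sapiens), with a stated time of 3 min (on this read-out lower numbers stand for stronger inhibition and higher numbers for weaker inhibition), compound 1 `CC(C)(C)C[C@@H](O)C(=O)N1N=CC[C@H]1C(=O)NCc1cc(Cl)ccc1-n1cnnn1` gives 590 nM and compound 2 `CC(C)CC[C@@H](O)C(=O)N1N=CC[C@H]1C(=O)NCc1cc(Cl)ccc1-n1cnnn1` gives 630 nM and so stands level with compound 1 within the scatter. Compound 3 `CCCC[C@@H](O)C(=O)N1N=CC[C@H]1C(=O)NCc1cc(Cl)ccc1-n1cnnn1` has hydrogen in place of methyl on a saturated chain carbon bound to two saturated chain carbons. Among the compounds with values here, the one measured step on this chain, isobutyl in place of tert-butyl, is a 1.1-fold higher number from compound 1 to compound 2 (0.03 log units; within the scatter) and so no step beyond the scatter is expected in this assay from this further change. The expected step is a 1.1-fold higher number from compound 2 to compound 3 (0.03 log units; within the scatter) on this estimate. Compound 3 is estimated at 680 nM (expected range 300 nM to 1500 nM).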

Compound 3, half-maximal inhibitory concentration: 610 nM
Compound 3: middle estimate off by 1.1-fold (0.05 log units), on the high side; measured number inside the range.
By their numbers in this assay, from the lowest: compounds 1, 3 and 2 (each within the scatter of the next).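

In this assay hydrogen in place of methyl on a saturated chain carbon bound to two saturated chain carbons gives a 1.0-fold lower number from compound 2 to compound 3 (0.01 log units; within the scatter) and so removes the branch without a step beyond the scatter. Taken from the tert-butyl end, propyl gives a 1.0-fold higher number from compound 1 to compound 3 (0.01 log units; within the scatter) and so the unbranched compound 3 stands level with the branched compound 1 and compound 2 in this assay as well.

From the compounds shown here alone, whether a longer chain, a phenyl ring or an amine at this chain end would hold the number remains open. Nothing available explains this flat response.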